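The source may report more compounds than this note shows. Statements on the series, on what has been measured and on what is new or still open speak of the compounds shown alone.

Measured compounds:
- compound 1, `CN1[C@@H]2c3[nH]c4ccccc4c3C[C@H]1[C@H](C#N)N1[C@@H](CN3C(=O)c4ccccc4C3=O)c3[nH]c4ccccc4c3C[C@@H]21`; in a functional assay on HT-29 cells (Homo sapiens) for cytotoxicity, read by MTT assay, with a stated time of 72 h (on this read-out higher numbers stand for weaker inhibition and lower numbers for stronger inhibition), compound 1 gives 80 nM
- compound 2, `CN1[C@@H]2c3[nH]c4ccccc4c3C[C@H]1[C@H](C#N)N1[C@@H](CNC(=O)c3ccc(Cl)cc3)c3[nH]c4ccccc4c3C[C@@H]21`; in this assay compound 2 gives 130 nM
- compound 3, `CN1[C@@H]2c3[nH]c4ccccc4c3C[C@H]1[C@H](C#N)N1[C@@H](CNC(=O)c3ccc4ccccc4n3)c3[nH]c4ccccc4c3C[C@@H]21`; in this assay compound 3 gives 150 nM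

Compound 2 holds the second highest of the three numbers. Its nearest neighbour is compound 3, with a 1.2-fold higher number from compound 2 to compound 3 (0.06 log units; within the scatter); the furthest is compound 1, with a 1.6-fold higher number from compound 1 to compound 2 (0.21 log units; within the scatter). Both steps lie within the scatter, so the three measured compounds cannot be ordered against one another.

Compound 4, `CN1[C@@H]2c3[nH]c4ccccc4c3C[C@H]1[C@H](C#N)N1[C@@H](CNC(=O)c3cc4ccccc4s3)c3[nH]c4ccccc4c3C[C@@H]21`, is not yet measured. Relative to compound 2 the change is 1-benzothiophen-2-yl in place of 4-chlorophenyl on a carbonyl carbon.

Going by the values given here, two measured steps bear on this position: the step from compound 1 to compound 2 changes the group on the saturated chain carbon, and the step from compound 2 to compound 3 swaps the aryl group on the same carbonyl carbon. Neither moves the number beyond the scatter. On that basis no step beyond the scatter is expected in this assay for a further aryl swap on the carbonyl carbon.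

Compound 4 is therefore expected to give about 140 nM, with a range of 60 nM to 330 nM. The expected step from compound 2 is a 1.1-fold higher number from compound 2 to compound 4 (0.03 log units; within the scatter).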

Compound 4, half-maximal inhibitory concentration: 640 nM
The estimate for compound 4 lay 4.6-fold (0.66 log units) below the measured number; measured number outside the range, above it.
By their numbers in this assay, from the lowest: compounds 1, 2 and 3 (each within the scatter of the next); then compound 4.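

In this assay, going by these compounds alone, 1-benzothiophen-2-yl in place of 4-chlorophenyl gives a 4.9-fold higher number from compound 2 to compound 4 (0.69 log units; beyond the scatter), and in place of quinolin-2-yl it gives a 4.3-fold higher number from compound 3 to compound 4 (0.63 log units; beyond the scatter), so an aryl swap on this carbonyl carbon can move the number beyond the scatter, which no earlier step showed. The change on the saturated chain carbon, read against the group of compound 1, gives an 8.0-fold higher number from compound 1 to compound 4 (0.90 log units; beyond the scatter), so the weaker number of compound 4 holds against all three other compounds. No measurement at hand speaks to why this group stands apart.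

Within the data shown here, with only one sulfur-bearing group in the set, it remains open whether the shift follows the five-membered aromatic ring alone or the whole 1-benzothiophen-2-yl group. Thiophen-2-yl or cyclohexyl on the same carbonyl carbon would test how far the shift extends.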